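Shared-core thioethers: the amide analogue of compound 3

This account rests on a few compounds, and the source may have more. Where it says the series, first, only, none or still open, it means among the compounds named here.

Values in a functional assay on HCT-116 cells (Homo sapiens) for inhibition, read by MTT assay, with a stated time of 48 h; a higher number here means a weaker inhibitor, a lower number a stronger inhibitor:
compound 1 `COc1ccc(-n2c(S)nnc2-c2cc(OC)c(OC)c(OC)c2)cc1` — > 60000 nM
compound 2 `COc1ccc(-n2c(SCc3ccccc3)nnc2-c2cc(OC)c(OC)c(OC)c2)cc1` — 42400 nM
compound 3 `COc1ccc(C(=O)CSc2nnc(-c3cc(OC)c(OC)c(OC)c3)n2-c2ccc(OC)cc2)cc1` — > 60000 nM

Compound 3 stands at a limit of the assay and gives no number in this assay. Compound 1 sits at the same limit. Compound 2 is the only one of the three that gives a number. Of the steps recorded, an at least 1.4-fold lower number from compound 1 to compound 2 (0.15 log units; that floor lies within the scatter) and an at least 1.4-fold higher number from compound 2 to compound 3 (0.15 log units; that floor lies within the scatter) read as floors only, and a step that the two limits leave unreadable from compound 1 to compound 3 cannot be read at all; the cause in each case is the limit of > 60000 nM in this assay, at which 2 of the 3 values shown sit.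

Compound 4 `COc1ccc(-n2c(SCC(=O)Nc3ccc(Cl)cc3)nnc2-c2cc(OC)c(OC)c(OC)c2)cc1` differs from compound 3 in one place: (4-chlorophenyl)amino in place of 4-methoxyphenyl on a carbonyl carbon. Among the measured compounds shown here, no measured step changes what sits on a carbonyl carbon; the recorded steps change what is bound to the sulfur or to the chain carbon, and the one that brings in the carbonyl, an at least 1.4-fold higher number from compound 2 to compound 3 (0.15 log units; that floor lies within the scatter), gives only a floor. For the measured compounds named here, the series therefore offers no step of the same kind from which the size of this change could be read. With compound 3 at the limit, the step of an at least 1.2-fold lower number from compound 3 to compound 4 (0.07 log units; that floor lies within the scatter) is expected to be small or not visible beyond the scatter, and a result at the limit again is quite possible. Compound 4 is estimated at 50000 nM, with a range from 15000 nM to 200000 nM.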

Compound 4, half-maximal inhibitory concentration: > 60000 nM
Compound 4: no number, only a limit; the forecaster's own chance of this, stated with the estimate: 55%; at least 1.2-fold (0.07 log units) between middle value and limit.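

Among the compounds shown here, the (4-chlorophenyl)amino group on the carbonyl carbon is the first change at this place, and it gives no number in this assay, so the amide, with its added hydrogen-bond donor, joins the aryl carbonyl analogue compound 3 at the limit rather than separating from it. For the compounds shown here, the only step to compound 4 that can be read at all is an at least 1.4-fold higher number from compound 2 to compound 4 (0.15 log units; that floor lies within the scatter), so the (4-chlorophenyl)carbamoyl group cannot be placed relative to phenyl on the saturated chain carbon bound to a sulfur. The steps to compound 4 from compound 1 and compound 3 cannot be read, because both ends of each are limits: the limit of > 60000 nM in this assay, at which 3 of the 4 values shown sit.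

Going by these compounds, whether anything on this carbonyl carbon can give a number in this assay stays open, and so does the size of any difference between 4-methoxyphenyl and (4-chlorophenyl)amino. A hydroxyl group, making a carboxylic acid, or a simple alkyl amine on the carbonyl carbon, or a longer chain on the sulfur, would each probe this part of the series beyond the two aromatic groups shown.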